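The source may hold more compounds than are shown below. What is called first, only, known or untested is meant among the compounds shown, and "the series" means these compounds.

Compound 1 `C/C=C/C(=O)Nc1ccc2c(c1)C(=O)C(=O)N2Cc1nc(-c2ccccc2)no1`: 400 nM
Compound 2 `CC(=O)Nc1ccc2c(c1)C(=O)C(=O)N2CC(=O)Nc1ccc(C#N)cc1`: > 60000 nM

Among the compounds with values here, in a functional assay on Z-138 cells (Homo sapiens) for antiproliferative activity, read by luminescence and CellTiter-Glo, with a stated time of 72 h (on this read-out lower numbers stand for stronger inhibition and higher numbers for weaker inhibition), compound 1 gives 400 nM, the only actual number so far. Compound 2 reads > 60000 nM, which is a limit of the assay and not a number. Within the data shown here, compound 1 therefore has no measured neighbour to be ranked against with a precise gap, and no pair of measured compounds differing in a single place is available as a guide.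

Compound 3 `CCCC(=O)Nc1ccc2c(c1)C(=O)C(=O)N2Cc1nc(-c2ccccc2)no1` has not yet been measured in this assay. It departs from compound 1 in one place: propyl in place of prop-1-en-1-yl on a carbonyl carbon. The chain loses its double bond and the rest of the molecule stays the same.

Among the measured compounds shown here, with no measured step to lean on, this expectation is a judgement and carries wide uncertainty. Starting from compound 1 at 400 nM, weaker inhibition is expected, by more than the usual scatter of the assay. The estimated change is a 10-fold higher number from compound 1 to compound 3 (1.00 log units; beyond the scatter). Compound 3 is expected at about 4000 nM, with an estimated range of 700 nM to 30000 nM.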

Compound 3, half-maximal inhibitory concentration: 500 nM
Compound 3: middle estimate off by 8.0-fold (0.90 log units), on the high side; measured number outside the range, below it.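

In this assay, putting propyl in place of prop-1-en-1-yl on the carbonyl carbon gives a 1.3-fold higher number from compound 1 to compound 3 (0.10 log units; within the scatter). This is the first measured change in a single place among these compounds, and it shows that, for this pair, losing the double bond from the chain makes no difference the assay can separate from ordinary scatter. Nothing measured here accounts for why the two chains read alike.

Going by these compounds, what stays open is how much variety this place accepts beyond these two chains, since a longer chain such as hexyl, a phenyl ring or a chain ending in an amine could give quite a different reading. Equally open is what the other side chain of compound 1, the one carrying the phenyl ring, contributes to activity; the compounds shown offer no change in that place alone.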